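This account rests on a few compounds, and the source may have more. Where it says the series, first, only, none or still open, it means among the compounds named here.

Three compounds share one core. Compound 1 `CS(=O)(=O)Cc1cc([C@]23CCOC[C@H]2C3)nc(-c2cccc(O)c2)n1` gives 3.7 in a physicochemical assay for lipophilicity; a higher number here means a more lipophilic compound, a lower number a more polar compound. Compound 2 `CC(C)(c1cc([C@@]23CCOC[C@@H]2C3)nc(-c2cccc(O)c2)n1)S(C)(=O)=O` gives 4.8 in this assay, and compound 3 `Oc1cccc(-c2nccc([C@@]34CCOC[C@@H]3C4)n2)c1` gives 4. Among these three numbers compound 3 stands second highest: its nearest neighbour is compound 1, a number within the scatter below it, and its furthest is compound 2, a number beyond the scatter above it. The one step that joins two of these compounds in a single place is a number 0.80 log units lower from compound 2 to compound 3 (beyond the scatter).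

Compound 4 `CS(=O)(=O)Cc1cc([C@@]23CCOC[C@@H]2C3)nc(-c2cccc(O)c2)n1` has not yet been measured in this assay. Compared with compound 3 it carries (methylsulfonyl)methyl in place of hydrogen on an aromatic carbon. The step from compound 2 to compound 3 bears on this change only loosely, since the group that leaves there is larger than the one that enters here, and it lowered the number modestly. The same (methylsulfonyl)methyl group that enters in compound 4 is carried by compound 1, which gives 3.7, a number within the scatter of compound 3. Taken together, compound 4 is expected to sit close to compound 3, with the change a number 0.20 log units lower from compound 3 to compound 4 (within the scatter) expected to stay within the scatter. The estimate for compound 4 is therefore 3.8, ranging from 3.3 to 4.3.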

Compound 4, partition coefficient: 3.7
For compound 4 the middle estimate is 0.10 log units above the measured one, within the range that was stated.
By their numbers in this assay, from the lowest: compounds 1, 4 and 3 (each within the scatter of the next); then compound 2.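

In this assay, setting (methylsulfonyl)methyl in place of hydrogen on the aromatic carbon next to the ring nitrogen gives a number 0.30 log units lower from compound 3 to compound 4 (within the scatter), so at this position the new group leaves the number indistinguishable from that of the unsubstituted compound. Among the compounds shown here, the larger 1-methyl-1-(methylsulfonyl)ethyl group behaves differently, as replacing it with (methylsulfonyl)methyl gives a number 1.10 log units lower from compound 2 to compound 4 (beyond the scatter), and compound 2 therefore stands apart from both compound 3 and compound 4, whereas the earlier compounds had set it apart from compound 3 alone. The result also adds a comparison of configuration, with no change at the digits printed from compound 1 to compound 4 (within the scatter), so in this pair the inversion of all stereocentres produces no difference beyond the scatter, and this step speaks to configuration rather than to any change of group: the fact that compounds 1 and 4 differ only in the configuration as drawn.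

The compounds shown leave open whether a 1-(methylsulfonyl)ethyl group, with a single methyl on the carbon that carries the sulfonyl, would read like (methylsulfonyl)methyl or like 1-methyl-1-(methylsulfonyl)ethyl. They also leave open how an amine or a carboxylic acid on the same aromatic carbon would read in this assay.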